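Removing a Methyl from an Aryl Ether in a Urea Series

A few compounds are considered here, and "the series" means these few. Any claim that something is new, unique, unknown or untested is made for them only; others in the source may bear on it.

Of the compounds shown here, two from this series have been tested in a functional assay on A375P cells (Homo sapiens) for antiproliferative activity, read by MTT assay, with a stated time of 48 h; a higher number here means a weaker inhibitor, a lower number a stronger inhibitor. Compound 1 `COc1cc(-c2nn(-c3ccc(NC(=O)Nc4cc(C(F)(F)F)cc(C(F)(F)F)c4)cc3)cc2-c2ccncc2)ccc1Cl` gives 11800 nM in this assay. Compound 2 `O=C(Nc1ccc(-n2cc(-c3ccncc3)c(-c3ccc(Cl)c(O)c3)n2)cc1)Nc1ccc(Cl)c(Cl)c1` gives 13500 nM in this assay. On the numbers shown, compound 1 stands at the lowest of the two, yet its gap to compound 2 lies within the usual scatter of repeated measurements, so the two cannot be told apart on these data.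

The next compound, compound 3 `O=C(Nc1ccc(-n2cc(-c3ccncc3)c(-c3ccc(Cl)c(O)c3)n2)cc1)Nc1cc(C(F)(F)F)cc(C(F)(F)F)c1`, has not yet been measured. It differs from compound 1 in one place, (hydrogen in place of methyl on an oxygen on an aromatic ring), that is, hydrogen in place of methyl on an oxygen on an aromatic ring, so that methoxy becomes hydroxy and 4-chloro-3-methoxyphenyl becomes 4-chloro-3-hydroxyphenyl. Among the measured compounds shown here, no pair of measured compounds shows what this change does, so the expectation rests on the small size of the change alone. The step is expected to be small, a 1.2-fold lower number from compound 1 to compound 3 (0.07 log units; within the scatter), and not beyond the scatter in either direction. Compound 3 is therefore expected to give about 10000 nM in this assay, with a range from 4000 nM to 30000 nM.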

Compound 3, half-maximal inhibitory concentration: > 20000 nM
Compound 3 gave a limit, no number; the forecaster's own chance of this, stated with the estimate: 5%; middle value at least 2.0-fold (0.30 log units) from the limit.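

Compound 3 gives > 20000 nM in this assay, which is a limit of the assay and not a number. Among the compounds shown here, this pair gives the first step that can be read at this position: going from methoxy to hydroxy means an at least 1.6-fold higher number from compound 1 to compound 3 (0.22 log units; that floor lies within the scatter), so putting hydrogen in place of the methyl on the oxygen brought no lower number here, although that floor alone does not separate the two compounds. The true size of the step remains unknown, and the reading for compound 3 stops at one edge of what the assay reports: the limit of > 20000 nM in this assay, at which 1 of the 3 values shown sits.

The compounds shown leave open how far compound 3 really lies from compound 1, and whether a number within the assay's range would put the step beyond the usual scatter. They also leave open whether the methyl itself matters or whether another group would serve as well, such as an ethyl or a longer chain on the same oxygen, or an amine in place of the hydroxy.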